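The source may hold more compounds than are shown below. What is called first, only, known or untested is meant among the compounds shown, and "the series" means these compounds.

Measured so far:
- compound 1, `Cc1cc(F)ccc1C1=Nc2c(Cl)cccc2SC(C(=O)O)C1`: > 20000000 nM
- compound 2, `Cc1cc(F)ccc1C1=Nc2c(Br)cccc2SC(C(=O)O)C1`: > 20000000 nM

In an ADME assay on NCTC-2544 cells (Homo sapiens, culture collection number NCTC 2544), read by MTT assay, with a stated time of 72 h (on this read-out lower numbers stand for stronger inhibition of growth and higher numbers for weaker inhibition of growth), compound 1 returns only a limit, > 20000000 nM. Compound 2 likewise returns only a limit, > 20000000 nM. Among the measured compounds shown here, compound 2 thus stands at the limit of > 20000000 nM in this assay, at which 2 of the 2 values shown sit, with no number of its own, and the single measured step, a step that the two limits leave unreadable from compound 1 to compound 2, cannot be read in either direction.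

Compound 3, `Cc1cc(F)ccc1C1=Nc2c(F)cccc2SC(C(=O)O)C1`, differs from compound 2 by fluoro in place of bromo on an aromatic carbon. For the measured compounds named here, the only measured step that bears on a change of halogen at this carbon is a step that the two limits leave unreadable from compound 1 to compound 2, and its size is not readable; no step in this assay shows movement beyond the scatter, and no numeric value exists to anchor one. No shift beyond the scatter is therefore expected, the step of a number no higher from compound 2 to compound 3 (the limit leaves the size open) being an expectation only. Compound 3 is estimated at 20000000 nM, with a range of 5000000 nM to 100000000 nM, and is most likely to be reported again as a limit.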

Compound 3, concentration for 50% growth inhibition: 7000000 nM
For compound 3 the middle estimate is 2.9-fold (0.46 log units) above the measured one; measured number inside the range.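

In this assay, fluoro on this aromatic carbon, ortho to a fused ring and meta to a fused ring, gives the only number of its own among the compounds shown, so the choice of halogen here can move the read-out: an at least 2.8-fold lower number from compound 2 to compound 3 (0.45 log units; beyond the scatter), and an at least 2.8-fold lower number from compound 1 to compound 3 (0.45 log units; beyond the scatter). Going by these compounds, both steps set only a least size, and the true gap from chloro or bromo to fluoro stays unknown, while the step between compound 1 and compound 2 cannot be read. Compound 1 and compound 2 both rest on a limit of the assay rather than a number: the limit of > 20000000 nM in this assay, at which 2 of the 3 values shown sit.

The compounds shown leave open whether hydrogen, a methoxy group or an amine on this carbon would give a number lower or higher than fluoro does. They also leave open what a methyl ester in place of the carboxylic acid would do to compound 3 in this assay.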